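The source may report more compounds than this note shows. Statements on the series, on what has been measured and on what is new or still open speak of the compounds shown alone.

For the measured compounds named here, compound 1 `CC1(C)CC(OC(=O)CN2CN(c3ccccc3)C3(CCN(C(=O)c4ccc(C5CCCCC5)cc4)CC3)C2=O)CC(C)(C)N1` gives 600 nM in an assay on HEK293 cells for displacement of a labelled ligand from NPC1-like intracellular cholesterol transporter 1 (Homo sapiens) (on this read-out higher numbers stand for weaker inhibition and lower numbers for stronger inhibition), the lowest of the three numbers measured so far; compound 2 `CC1(C)CC(OC(=O)CN2CN(c3ccccc3)C3(CCN(C(=O)c4ccc(C(C)(C)C)cc4)CC3)C2=O)CC(C)(C)N1` gives 1300 nM and compound 3 `O=C(CN1CN(c2ccccc2)C2(CCN(C(=O)c3ccc(C4CCCCC4)cc3)CC2)C1=O)N1CCN(S(=O)(=O)c2ccccc2)CC1` gives 14200 nM. Compound 4 `O=C(CN1CN(c2ccccc2)C2(CCN(C(=O)c3ccc(C4CCCCC4)cc3)CC2)C1=O)NCO` carries (hydroxymethyl)amino in place of (2,2,6,6-tetramethylpiperidin-4-yl)oxy on a carbonyl carbon. Going by the values given here, the one measured step, a 2.2-fold higher number from compound 1 to compound 2 (0.34 log units; beyond the scatter), concerns a group on an aromatic carbon and does not bear on this change. Among the compounds with values here, compound 1 and compound 3 differ at the carbonyl carbon in question, and their two values show a far higher number once the (2,2,6,6-tetramethylpiperidin-4-yl)oxy group is gone, though no step between them is given. A higher number is therefore expected for compound 4, beyond the scatter, with the smaller (hydroxymethyl)amino group not necessarily reaching compound 3. Compound 4 is estimated at 5000 nM, range 1500 nM to 20000 nM, which means an expected step of an 8.3-fold higher number from compound 1 to compound 4 (0.92 log units; beyond the scatter).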

Compound 4, half-maximal inhibitory concentration: 8300 nM
The estimate for compound 4 lay 1.7-fold (0.22 log units) below the measured number; the range from low to high includes it.
By their numbers in this assay, from the lowest: compound 1; then compound 2; then compounds 4 and 3 (each within the scatter of the next).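

For the compounds shown here, on the carbonyl carbon, (hydroxymethyl)amino in place of (2,2,6,6-tetramethylpiperidin-4-yl)oxy gives a 14-fold higher number from compound 1 to compound 4 (1.14 log units; beyond the scatter) and this is the first step readable at this position. Compound 3 at 14200 nM and compound 4 at 8300 nM lie within the scatter of each other, so neither replacement on the carbonyl carbon stands apart from the other. The data on hand offer no evidence that accounts for this step.
On these data alone, whether the lower number of compound 1 rests on the ring nitrogen or on the ester oxygen stays open. A cyclohexyl ester or a 2,2,6,6-tetramethylpiperidin-4-yl amide at this carbonyl carbon would separate the two.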